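This account rests on a few compounds, and the source may have more. Where it says the series, first, only, none or still open, it means among the compounds named here.

Compounds measured so far:
compound 1 `Cc1nc(N)nc(Nc2cccc(Cl)c2)n1`, value in an assay for inhibition of Dihydrofolate reductase (Bos taurus), using NADPH; a lower number here means a stronger inhibitor, a higher number a weaker inhibitor: > 100000 nM
compound 2 `Cc1nc(N)nc(Nc2ccc(Cl)c(Cl)c2)n1`, value in this assay: > 100000 nM

Both values shown are limits of the assay, not numbers. In this assay compound 1 gives only the limit > 100000 nM. In this assay compound 2 likewise gives only the limit > 100000 nM. The step that the two limits leave unreadable from compound 1 to compound 2 is therefore not readable in size, and the limit of > 100000 nM in this assay, at which 2 of the 2 values shown sit, records where both values sit. On the numbers shown, compound 2 stands at the limit of the assay, with nothing placing it more closely.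

Compound 3 `Nc1nc(CCl)nc(Nc2ccc(Cl)c(Cl)c2)n1` differs from compound 2 by chloro in place of hydrogen on a saturated chain carbon bound to an aromatic carbon. Among the measured compounds shown here, no measured step bears on this change: the single measured step concerns a chloro on an aromatic carbon, and its size cannot be read from the two limits. With compound 2 sitting at the limit, compound 3 is expected to remain at or near that limit, so the step of a number no higher from compound 2 to compound 3 (the limit leaves the size open) is expected to be none that can be resolved. In this assay compound 3 is estimated at 100000 nM, within the range 20000 nM to 500000 nM, and is expected most likely to be reported again only as a limit.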

Compound 3, half-maximal inhibitory concentration: > 100000 nM
Compound 3: a limit, no number (the forecaster's own chance of this, stated with the estimate: 70%); the middle value lies on the limit itself.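

Compound 3, like compound 2, gives only a limit in this assay, not a number, so no step between compound 2 and compound 3 can be read: the limit of > 100000 nM in this assay, at which 3 of the 3 values shown sit.

The compounds shown leave open whether either the methyl to chloromethyl change or the added chloro on an aromatic carbon alters inhibition, since none gives a measurable value.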